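This account rests on a few compounds, and the source may have more. Where it says the series, first, only, none or still open, it means among the compounds named here.

Measured compounds:
- compound 1, `COc1cc2cc(Oc3ccc(NC(=O)Nc4ccccc4)cc3)c(C)nc2cc1OC`: 58.4%
- compound 2, `COc1cc2cc(Oc3ccc(NC(=O)Nc4ccc(C)cc4)cc3)c(C)nc2cc1OC`: 102%
- compound 3, `COc1cc2cc(Oc3ccc(NC(=O)Nc4cccc(C(F)(F)F)c4)cc3)c(C)nc2cc1OC`: 3.09%

In a functional assay on A549 cells (Homo sapiens) for inhibition, read by sulforhodamine B assay, with a stated time of 48 h, tested at 10 uM (on this read-out higher numbers stand for a weaker effect at the one concentration tested and lower numbers for a stronger effect), compound 3 gives the lowest number of the three, so it shows the strongest effect; compound 1 comes nearest with 58.4% and compound 2 sits furthest away with 102%. Compound 4, `COc1cc2cc(Oc3ccc(NC(=O)Nc4ccc(Cl)c(Cl)c4)cc3)c(C)nc2cc1OC`, has not yet been measured. It differs from compound 3 in one place: 3,4-dichlorophenyl in place of 3-(trifluoromethyl)phenyl on an amide-type nitrogen.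

Among the measured compounds shown here, two measured steps bear on this position. Going from a plain phenyl to the trifluoromethyl-bearing ring gave a number 55.3 percentage points lower from compound 1 to compound 3 (beyond the scatter), and going from the 4-methylphenyl to the same ring gave a number 98.9 percentage points lower from compound 2 to compound 3 (beyond the scatter). For the measured compounds named here, both show that what sits on this outer ring moves this assay a long way, and that compound 3 carries the arrangement with the lowest number so far. Going by the values given here, no measured compound carries a 3,4-dichlorophenyl, so the direction of the new step rests on the observation that compound 3 already lies near the bottom of the scale; little room remains below it. For compound 4 the expected step is a number 11.9 percentage points higher from compound 3 to compound 4 (beyond the scatter), a modest rise that may fall within the scatter. Compound 4 is therefore estimated at 15%, with a likely range from 2% to 60%.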

Compound 4, a percentage reported as activity, at one concentration (the size of the read-out at that concentration, not a potency): 4.35%
Estimate against measurement, compound 4: 10.7 percentage points above; the measured number falls inside the stated range.
By their numbers in this assay, from the lowest: compounds 3 and 4 (each within the scatter of the next); then compound 1; then compound 2.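

In this assay, the change of outer ring gives a number 1.3 percentage points higher from compound 3 to compound 4 (within the scatter), so the low number at this position is not tied to the trifluoromethyl group: a 3,4-dichlorophenyl serves equally well. The same ring also gives a number 54.1 percentage points lower from compound 1 to compound 4 (beyond the scatter) and a number 97.7 percentage points lower from compound 2 to compound 4 (beyond the scatter), so two differently substituted rings now lie far below the plain phenyl, while compound 2 shows that a substituent alone is not enough, since its 4-methylphenyl goes against any such rule. Nothing measured here explains why these two rings match.

The compounds shown leave open whether one chlorine would do as well as two, and how a ring bearing an amine or a carboxylic acid would behave. With only one concentration tested, they also cannot separate compound 3 from compound 4 in potency.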